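The source may hold more compounds than are shown below. What is called first, only, known or untested is meant among the compounds shown, and "the series" means these compounds.

Measured compounds and their values:
compound 1, `C=CCn1c(=O)n(CCCC)c2nc(N)nc(O)c21`, gives 2 uM;
compound 2, `C=CCn1c(=O)n(Cc2ccccc2)c2nc(N)nc(O)c21`, gives 5 uM;
compound 3, `CCCCn1c(=O)n(C2OC(CO)[C@@H](O)[C@H]2O)c2nc(N)nc(O)c21`, gives 11 uM.

All three were tested in a functional assay (B cells) with Mus musculus as the target; a higher number here means that more compound is needed for the effect, a lower number that less compound is needed. Compound 1 and compound 2 share one core and differ in a single place, (phenyl in place of propyl on a saturated chain carbon bound to an aromatic nitrogen); that change brought a 2.5-fold higher number from compound 1 to compound 2 (0.40 log units; beyond the scatter). Compound 3 carries a different core, and the difference between the two cores is not broken down here; its value is the highest of the three, beyond the scatter from both compound 1 and compound 2.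

Compound 4, `Nc1nc(O)c2c(n1)n(C1OC(CO)[C@@H](O)[C@H]1O)c(=O)n2Cc1ccccc1`, is not yet measured. It stands to compound 3 as compound 2 stands to compound 1: phenyl in place of propyl on a saturated chain carbon bound to an aromatic nitrogen, the same change at the same place. Resting on the step seen from compound 1 to compound 2, a 2.5-fold higher number from compound 1 to compound 2 (0.40 log units; beyond the scatter), a step of similar size is expected from compound 3 to compound 4 in this assay, namely a 2.3-fold higher number from compound 3 to compound 4 (0.36 log units; beyond the scatter). On that basis compound 4 is estimated at 25 uM, with a likely range from 10 uM to 60 uM, and the higher starting point of compound 3 makes a limit rather than a number somewhat more likely than for the others.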

Compound 4, concentration for half-maximal effect: 6 uM
Compound 4: middle estimate off by 4.2-fold (0.62 log units), on the high side, and the stated range ends above it.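

In this assay, the change from butyl to benzyl gave a 1.8-fold lower number from compound 3 to compound 4 (0.26 log units; within the scatter), a step within the usual scatter of repeated measurements, whereas on the core of compound 1 it gave a 2.5-fold higher number from compound 1 to compound 2 (0.40 log units; beyond the scatter). The step seen on one core therefore did not carry over to the other, and the gap between the two steps is larger than scatter alone would explain: the same change on two cores in this assay, a 2.5-fold higher number (0.40 log units; beyond the scatter) from compound 1 to compound 2 and a 1.8-fold lower number (0.26 log units; within the scatter) from compound 3 to compound 4, 4.6-fold (0.66 log units) apart, beyond the scatter of two such steps This rests on a single pair for each core, so it warns against transferring the step from one core to the other in this series, but it does not show what in the cores causes the difference, nor how the change would behave on any third core.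

The compounds shown leave open how other groups at this place would read on the two cores, such as a longer chain like hexyl, or a benzyl carrying an amine or a carboxylic acid. They also leave open whether such groups would give matching or differing steps on the two cores.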